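Replacing methylamino with chloro in compound 3

The source may hold more compounds than are shown below. What is called first, only, known or untested is meant among the compounds shown, and "the series" means these compounds.

In an ADME assay on L6 cells (Rattus norvegicus) for inhibition, read by resazurin assay, with a stated time of 72 h (on this read-out lower numbers stand for stronger inhibition and higher numbers for weaker inhibition), compound 3 `CNc1nc(NC)c2ncn([C@@H]3O[C@H](C)[C@@H](O)[C@H]3O)c2n1` gives 187000 nM. Compound 2 `CS(=O)(=O)C[C@H]1O[C@@H](n2cnc3c(N)nc(Cl)nc32)[C@H](O)[C@@H]1O` gives 156000 nM, within the scatter of compound 3, while compound 1 `CS(=O)(=O)C[C@H]1O[C@@H](n2cnc3c(N)nc(F)nc32)[C@H](O)[C@@H]1O` gives a much lower 5000 nM. Compound 4 `CNc1nc(Cl)c2ncn([C@@H]3O[C@H](C)[C@@H](O)[C@H]3O)c2n1`, not yet measured, has chloro in place of methylamino on an aromatic carbon. Within the data shown here, the only measured step, a 31-fold higher number from compound 1 to compound 2 (1.49 log units; beyond the scatter), is large, but it puts chloro in place of fluoro, so it shows only that one small swap can matter and is a weak guide here. With compound 3 at 187000 nM and compound 1 at 5000 nM, a moderately lower number seems likelier than a higher one in this assay. The expected change is a 3.1-fold lower number from compound 3 to compound 4 (0.49 log units; beyond the scatter). For compound 4 the estimated value is 60000 nM, with an expected range of 10000 nM to 200000 nM.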

Compound 4, half-maximal inhibitory concentration: 175000 nM
For compound 4 the middle estimate is 2.9-fold (0.46 log units) below the measured one; the measured number falls inside the stated range.
By their numbers in this assay, from the lowest: compound 1; then compounds 2, 4 and 3 (each within the scatter of the next).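

In this assay, a 1.1-fold lower number from compound 3 to compound 4 (0.03 log units; within the scatter) falls within the scatter, so on this aromatic carbon methylamino and chloro cannot be told apart, even though chloro has no hydrogen-bond donor. Among these compounds, this differs from the only earlier step, a 31-fold higher number from compound 1 to compound 2 (1.49 log units; beyond the scatter), where one swap of a group on the core of compound 1 moved the number well beyond the scatter. No measurement offers a reason for this result.

From the compounds shown here alone, whether a methoxy group or a longer chain such as propylamino on this carbon would give a number apart from compound 3 remains open. So does whether the same swap would be as silent on the core of compound 1.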